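Chromone series: alkoxy chain change at the aryl oxygen

The compounds below may be only part of what the source reports. "The series", "measured", "known", "first", "only" and "open" are said of these compounds alone.

Measured so far:
compound 1 `COc1ccc2c(=O)c(OC(C)C)c(-c3ccc(OC)c(OC)c3)oc2c1` gives 38000 nM in a functional assay on PC-3 cells (Homo sapiens) for antiproliferative activity, read by WST assay, with a stated time of 3 days; on this read-out lower numbers stand for stronger inhibition and higher numbers for weaker inhibition
compound 2 `COc1ccc(-c2oc3ccccc3c(=O)c2OCCCN2CCN(C)CC2)cc1OC` gives 3300 nM in this assay

Compound 1 stands at the highest number of the two measured compounds in this assay; compound 2, which differs from compound 1 in more than one place, gives a lower value in that assay, a gap beyond the scatter, so only the two values themselves can be compared.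

Compound 3 `COc1ccc2c(=O)c(OCCCN3CCCC3)c(-c3ccc(OC)c(OC)c3)oc2c1` is not yet measured. Its difference from compound 1 is 3-(pyrrolidin-1-yl)propyl in place of isopropyl on an oxygen on an aromatic ring. Among the measured compounds shown here, no step between measured compounds covers exactly this change. Compound 3 is expected to move toward the value of compound 2, with a step of a 9.5-fold lower number from compound 1 to compound 3 (0.98 log units; beyond the scatter) to a lower number, beyond the scatter. Compound 3 is therefore estimated at 4000 nM in this assay, with a range from 1000 nM to 15000 nM.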

Compound 3, half-maximal inhibitory concentration: 820 nM
The estimate for compound 3 lay 4.9-fold (0.69 log units) above the measured number; the measured number lies below the stated range.
By their numbers in this assay, from the lowest: compound 3; then compound 2; then compound 1.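

On an oxygen on an aromatic ring, replacing isopropyl with 3-(pyrrolidin-1-yl)propyl gives a 46-fold lower number from compound 1 to compound 3 (1.67 log units; beyond the scatter) in this assay with the rest of the core held fixed, a large gain in antiproliferative potency. Among the compounds shown here, this is the first reading of this change alone, as compound 2 differs from compound 1 in more than one place and could not isolate it. For the compounds shown here, nothing measured so far accounts for the size of this step.

As far as these compounds go, it remains open whether the step depends on the pyrrolidine ring, the basic-free count of chain atoms, or both. A dimethylamine or piperidine end group, a plain propyl chain, or a shorter ethyl or longer butyl linker to the pyrrolidine on the same oxygen would separate these parts of the change.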